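Acetyl(methylsulfonyl)amino replacing the sulfamoyl group on the aryl ring

A few compounds are considered here, and "the series" means these few. Any claim that something is new, unique, unknown or untested is made for them only; others in the source may bear on it.

The series shares one core and differs on the aryl ring that carries the sulfonyl group. For the measured compounds named here, in an assay on cells for antagonist activity at transient receptor potential cation channel subfamily V member 1 (Homo sapiens), read by FLIPR and calcium flux, with a stated time of 15 min (on this read-out higher numbers stand for weaker inhibition and lower numbers for stronger inhibition), compound 1 `Cc1cc(C(C)C(=O)NCc2ccc(C(F)(F)F)nc2N2CCC(C)CC2)ccc1NS(C)(=O)=O` gives 0.6 nM, and compound 2 `COc1cc(C(C)C(=O)NCc2ccc(C(F)(F)F)nc2N2CCC(C)CC2)ccc1NS(C)(=O)=O` gives 0.8 nM; the only single-point step among them is a 1.3-fold higher number from compound 1 to compound 2 (0.12 log units; within the scatter). Compound 3 `CC1CCN(c2nc(C(F)(F)F)ccc2CNC(=O)C(C)c2ccc(NS(=O)(=O)N(C)C)c(F)c2)CC1` stands apart with 42 nM, the highest number of the three, well beyond the scatter from both compound 1 and compound 2.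

Compound 4 `CC(=O)N(c1ccc(C(C)C(=O)NCc2ccc(C(F)(F)F)nc2N2CCC(C)CC2)cc1F)S(C)(=O)=O` is derived from compound 3 by acetyl(methylsulfonyl)amino in place of (dimethylsulfamoyl)amino on an aromatic carbon. Going by the values given here, no measured step bears directly on this change: the sole step, from methyl to methoxy, touches a different group and was within the scatter. What the values show is that both compounds bearing the methylsulfonyl group give far lower numbers than compound 3. Compound 4 regains that methylsulfonyl group but loses the hydrogen-bond donor, so compound 4 is expected to move toward lower numbers than compound 3, with the step from compound 3 to compound 4 estimated at a 2.8-fold lower number from compound 3 to compound 4 (0.45 log units; beyond the scatter). For compound 4 the estimate in this assay is 15 nM, in a range from 2 nM to 120 nM.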

Compound 4, inhibition constant: 11.9 nM
The estimate for compound 4 lay 1.3-fold (0.10 log units) above the measured number; measured number inside the range.
By their numbers in this assay, from the lowest: compounds 1 and 2 (each within the scatter of the next); then compound 4; then compound 3.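

On an aromatic carbon ortho to a fluoro group and para to a large group, the swap of (dimethylsulfamoyl)amino for acetyl(methylsulfonyl)amino gives, in this assay, a 3.5-fold lower number from compound 3 to compound 4 (0.55 log units; beyond the scatter), a modest step that lies beyond the scatter. Compound 4 is the only compound shown whose group at this place has 0 hydrogen-bond donors, so a hydrogen-bond donor there is not required for a number lower than that of compound 3. No measurement shown gives a reason for this step.

The change replaces the whole group at once, so the share of the acetyl and the share of the methylsulfonyl in the step remain apart from nothing shown here. Also open, going by these compounds, is how a propanoyl group on the same nitrogen, or a free amine at this place, would read in this assay.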